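Amide Nitrogen Substitution in a Menthol-Free Cooling Agonist Series

The source may hold more compounds than are shown below. What is called first, only, known or untested is meant among the compounds shown, and "the series" means these compounds.

Three measured compounds share an aryloxyacetamide core carrying a thiophenylmethyl group on the amide nitrogen. Compound 1 `CCN(Cc1cccs1)C(=O)COc1cc(C)ccc1O` gives 24 nM in an assay on HEK293 cells for agonist activity at transient receptor potential cation channel subfamily M member 8 (Homo sapiens), read by fluorescence and calcium flux, with a stated time of 15 min; a lower number here means that less compound is needed, a higher number that more compound is needed for the effect. Compound 3 `Cc1ccc(OCC(=O)N(C)Cc2cccs2)cc1` gives 400 nM in this assay. Compound 2 `CCN(Cc1cccs1)C(=O)COc1ccc2c(c1)CCC2` gives 0.8 nM in this assay, the lowest of the three numbers; compound 1 sits closest to it and still lies beyond the scatter, while compound 3 is furthest away, also beyond the scatter.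

Compound 4 `O=C(COc1ccc2c(c1)CCC2)N(Cc1cccs1)c1ccn[nH]1` differs from compound 2 in one place: 1H-pyrazol-5-yl in place of ethyl on an amide-type nitrogen. Going by the values given here, no pair among the measured compounds shows this kind of change, so no measured step can be drawn on; the three measured compounds differ at the aryl ether and at the amide nitrogen in other ways, and a step at the nitrogen from ethyl to a ring has not been seen here.

In the absence of such a step, the change is expected to cost some potency rather than none, with the step of a 5.0-fold higher number from compound 2 to compound 4 (0.70 log units; beyond the scatter) estimated as modest. For compound 4 the estimate is 4 nM in this assay, with an expected range from 0.8 nM to 20 nM.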

Compound 4, half-maximal effective concentration in the transient receptor potential cation channel subfamily M member 8 assay: 0.001 nM
Estimate against measurement, compound 4: 4000-fold (3.60 log units) above; measured number outside the range, below it.
By their numbers in the transient receptor potential cation channel subfamily M member 8 assay, from the lowest: compound 4; then compound 2; then compound 1; then compound 3.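

In the transient receptor potential cation channel subfamily M member 8 assay, 1H-pyrazol-5-yl in place of ethyl on the amide-type nitrogen gives an 800-fold lower number from compound 2 to compound 4 (2.90 log units; beyond the scatter), the largest gap among the compounds that can be compared in one place. The earlier compounds shown here carried only ethyl or methyl on this nitrogen, so they could not show that a five-membered aromatic ring is accepted here, or that it can take the number so far down. The change also has a measured cost in a physicochemical assay for solubility, measured as thermodynamic solubility, at pH 7.1; a higher number here means a more soluble compound, a lower number a less soluble compound: the measured solubility of compound 2, 85000 nM, and of compound 4, 26000 nM, a 3.3-fold lower number (0.51 log units; beyond the scatter) In the physicochemical assay compound 2 gives 85000 nM, and compound 4 gives 26000 nM.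

The compounds shown do not tell whether the drop depends on the aromatic ring itself or on the hydrogen-bond donor it brings, a question that a phenyl ring or a pyrazole with a methyl group on its ring nitrogen, placed on this amide-type nitrogen, would bear on. Also open is whether the same exchange would give a step of similar size on the aryl ether of compound 1 or compound 3, since only the core of compound 2 is shown with this ring.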